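Furan and benzofuran pairs on a shared ribosyl core

The source may hold more compounds than are shown below. What is called first, only, known or untested is meant among the compounds shown, and "the series" means these compounds.

Measured compounds:
- compound 1 `Cc1nc(N)c2c(-c3ccoc3)cn([C@@H]3O[C@H](CO)[C@@H](O)[C@H]3O)c2n1`: > 20000 nM
- compound 2 `Cc1nc(N)c2c(-c3cc4ccccc4o3)cn([C@@H]3O[C@H](CO)[C@@H](O)[C@H]3O)c2n1`: > 20000 nM
- compound 3 `Nc1nc(N)c2c(-c3ccoc3)cn([C@@H]3O[C@H](CO)[C@@H](O)[C@H]3O)c2n1`: > 20000 nM

All values come from a functional assay on HeLa S3 cells (Homo sapiens) for antiproliferative activity, read by XTT assay, with a stated time of 72 h; a lower number here means a stronger inhibitor, a higher number a weaker inhibitor. In this assay compound 1 gives > 20000 nM, which is a limit of the assay and not a number. Compound 2 gives > 20000 nM, again a limit of the assay. Compound 3 gives > 20000 nM, also a limit of the assay. Every value shown sits at the limit of > 20000 nM in this assay, at which 3 of the 3 values shown sit.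

Compound 2 differs from compound 1 by 1-benzofuran-2-yl in place of furan-3-yl on an aromatic carbon. The step that the two limits leave unreadable from compound 1 to compound 2 cannot be read, both ends being limits. Compound 3 differs from compound 1 by amino in place of methyl on an aromatic carbon, and the step that the two limits leave unreadable from compound 1 to compound 3 is likewise unreadable for the same reason.

The unmeasured compound 4 `Nc1nc(N)c2c(-c3cc4ccccc4o3)cn([C@@H]3O[C@H](CO)[C@@H](O)[C@H]3O)c2n1` differs from compound 3 by 1-benzofuran-2-yl in place of furan-3-yl on an aromatic carbon. Going by the values given here, this is the same change as the one made from compound 1 to compound 2: the two place descriptions agree word for word. The cores of compound 3 and compound 1 differ as described above by amino in place of methyl on an aromatic carbon.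

Among the compounds with values here, the only precedent, a step that the two limits leave unreadable from compound 1 to compound 2, gives no measurable size, and compound 3 itself stands at the assay limit. Compound 4 is therefore expected to remain at or beyond the limit as well, with an estimated step that the limit leaves unreadable from compound 3 to compound 4. The estimate for compound 4 is 40000 nM, with a range from 15000 nM to 200000 nM, resting on the limits seen for compound 1, compound 2 and compound 3.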

Compound 4, half-maximal inhibitory concentration: > 20000 nM
Compound 4 ended at the assay's limit; the forecaster's own chance of this, stated with the estimate: 90%; the middle value is on the limit's open side.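

In this assay compound 4 gives > 20000 nM, which is a limit of the assay and not a number. The steps from compound 3 to compound 4 and from compound 2 to compound 4 cannot be read, both ends being limits: the limit of > 20000 nM in this assay, at which 4 of the 4 values shown sit. The compounds shown leave open whether exchanging furan-3-yl for 1-benzofuran-2-yl, or methyl for amino, changes antiproliferative activity on the shared core at all.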